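The compounds below may be only part of what the source reports. "The series", "measured", "known", "first", "only" and "open" are said of these compounds alone.

Working notes on the amide series in a functional assay on HL-60 cells (Homo sapiens) for antiproliferative activity, with a stated time of 24 h; a lower number here means a stronger inhibitor, a higher number a weaker inhibitor.

Compound 3 `NC(=O)c1c(NC(=O)c2ccccc2Cl)sc2c1CCN(C(=O)Nc1ccccc1Cl)C2` gives 12500 nM and has the highest number of the three measured. Compound 1 `NC(=O)c1c(NC(=O)c2ccccc2Cl)sc2c1CCN(Cc1ccccc1Cl)C2` gives 2900 nM; compound 2 `Cc1ccc(C(=O)Nc2sc3c(c2C(N)=O)CCN(Cc2c(Cl)cccc2Cl)C3)cc1` gives 10000 nM. The gap between compound 3 and compound 2 lies within the scatter; the only listed step that reaches compound 3 is a 4.3-fold higher number from compound 1 to compound 3 (0.63 log units; beyond the scatter).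

Compound 4 `Cc1ccc(C(=O)Nc2sc3c(c2C(N)=O)CCN(C(=O)Nc2ccccc2Cl)C3)cc1` is not yet measured. It differs from compound 3 in one place: 4-methylphenyl in place of 2-chlorophenyl on a carbonyl carbon. Among the measured compounds shown here, no measured step covers exactly this exchange. Compound 1 and compound 2 differ in the same acyl group, but also in the group on the ring amine, so their values show only that the pairing of the 4-methylphenyl carbonyl with a dichlorobenzyl amine sits at a high number. Compound 4 holds that same 4-methylphenyl carbonyl together with the carbamoyl amine of compound 3, and a weak result is therefore expected, with the step of a 1.2-fold higher number from compound 3 to compound 4 (0.08 log units; within the scatter) likely within the scatter or slightly upward. For compound 4 the expected value is 15000 nM, estimated between 6000 nM and 40000 nM.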

Compound 4, half-maximal inhibitory concentration: 14600 nM
The estimate for compound 4 lay 1.0-fold (0.01 log units) above the measured number; measured number inside the range.
By their numbers in this assay, from the lowest: compound 1; then compounds 2, 3 and 4 (each within the scatter of the next).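

In this assay, the exchange on the carbonyl carbon can now be read on its own: 4-methylphenyl in place of 2-chlorophenyl gives a 1.2-fold higher number from compound 3 to compound 4 (0.07 log units; within the scatter) and does not separate from the scatter while the (2-chlorophenyl)carbamoyl group stays on the ring amine. With the 4-methylphenyl carbonyl held, (2-chlorophenyl)carbamoyl in place of 2,6-dichlorobenzyl gives a 1.5-fold higher number from compound 2 to compound 4 (0.16 log units; within the scatter) and also stays within the scatter. That contrasts with a 4.3-fold higher number from compound 1 to compound 3 (0.63 log units; beyond the scatter) for the 2-chlorophenyl carbonyl, although the two steps start from different benzyl groups, so the contrast cannot be assigned to the carbonyl group alone.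

Open, as far as these compounds go, is whether 4-methylphenyl on the carbonyl carbon would behave the same with 2-chlorobenzyl on the ring amine, and whether a carboxylic acid or a longer chain there would move the number. Nothing available here gives a reason for these results.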